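The source may report more compounds than this note shows. Statements on the series, on what has been measured and on what is new or still open speak of the compounds shown alone.

Measured so far in a functional assay on RAW264.7 cells (Mus musculus) for inhibition, read by Griess assay, with stated times of 2 h and 24 h; on this read-out higher numbers stand for weaker inhibition and lower numbers for stronger inhibition:
compound 1 `COc1ccc([C@@H]2CC(=O)c3c(O)cc(OCc4cn(Cc5ccc(C(F)(F)F)cc5)nn4)cc3O2)cc1O`: 17700 nM
compound 2 `COc1ccc([C@@H]2CC(=O)c3c(O)cc(OCc4cn(Cc5ccccc5C(F)(F)F)nn4)cc3O2)cc1O`: 12500 nM
compound 3 `COc1ccc([C@@H]2CC(=O)c3c(O)cc(OCc4cn(Cc5ccccc5Cl)nn4)cc3O2)cc1O`: 6140 nM

Compound 1 gives the highest of the three numbers in this assay. Compound 2 stays within the scatter of it (a 1.4-fold lower number from compound 1 to compound 2 (0.15 log units; within the scatter)), whereas compound 3 lies beyond it (a 2.9-fold lower number from compound 1 to compound 3 (0.46 log units; beyond the scatter)). Compound 4 `COc1ccc([C@@H]2CC(=O)c3c(O)cc(OCc4cn(Cc5ccccc5C)nn4)cc3O2)cc1O` has not been measured. It differs from compound 1 in one place: 2-methylphenyl in place of 4-(trifluoromethyl)phenyl on a saturated chain carbon bound to an aromatic nitrogen.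

Among the measured compounds shown here, two measured steps bear on this change, since both exchange 4-(trifluoromethyl)phenyl on a saturated chain carbon bound to an aromatic nitrogen for another phenyl: a 1.4-fold lower number from compound 1 to compound 2 (0.15 log units; within the scatter) and a 2.9-fold lower number from compound 1 to compound 3 (0.46 log units; beyond the scatter). Between those two outcomes stands a 2.0-fold lower number from compound 2 to compound 3 (0.31 log units; beyond the scatter). Methyl has no direct counterpart among the measured compounds, so its number is taken to fall between the results for compound 2 and compound 3. Compound 4 is therefore expected to give a modestly lower number than compound 1, a 2.1-fold lower number from compound 1 to compound 4 (0.32 log units; beyond the scatter). In this assay compound 4 is estimated at 8500 nM, with a range from 4200 nM to 17000 nM.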

Compound 4, half-maximal inhibitory concentration: 13100 nM
Compound 4: middle estimate off by 1.5-fold (0.19 log units), on the low side; low and high end bracket the measured number.
By their numbers in this assay, from the lowest: compound 3; then compounds 2, 4 and 1 (each within the scatter of the next).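

In this assay, 2-methylphenyl in place of 4-(trifluoromethyl)phenyl on a saturated chain carbon bound to an aromatic nitrogen does not separate from the scatter (a 1.4-fold lower number from compound 1 to compound 4 (0.13 log units; within the scatter)), and the change from trifluoromethyl to methyl does not separate either (a 1.0-fold higher number from compound 2 to compound 4 (0.02 log units; within the scatter)). Methyl in place of chloro on an aromatic carbon does separate (a 2.1-fold higher number from compound 3 to compound 4 (0.33 log units; beyond the scatter)), so among these four compounds only the 2-chlorophenyl group of compound 3 stands apart, and compounds 1, 2 and 4 do not resolve from one another. No measurement at hand accounts for this difference between chloro and methyl.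

Open, as far as these compounds go, is whether bromo or methoxy in place of chloro on an aromatic carbon would match compound 3 at 6140 nM or depart from it. Also open, from the compounds shown here alone, is how a longer chain in place of the 2-chlorobenzyl group would read.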